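The source may hold more compounds than are shown below. What is called first, only, known or untested is meant among the compounds shown, and "the series" means these compounds.

Compound 1 `Cc1ccc(NC(=O)NC(=O)c2ccc(OCc3cccc(Cl)c3)cc2)cc1-c1nc2ccccc2[nH]1` gives 20800 nM in a functional assay on MGC-803 cells (Homo sapiens) for inhibition, read by MTT assay, with a stated time of 48 h; a higher number here means a weaker inhibitor, a lower number a stronger inhibitor. Compound 2 `Cc1ccc(NC(=O)NC(=O)c2ccc(OCc3ccccc3F)cc2)cc1-c1nc2ccccc2[nH]1` gives 2520 nM in this assay, a change of an 8.3-fold lower number from compound 1 to compound 2 (0.92 log units; beyond the scatter). Compound 3 `Cc1ccc(NC(=O)NC(=O)c2ccc(OCc3cccc(Cl)c3Cl)cc2)cc1-c1nc2ccccc2[nH]1` reaches only the limit of the assay, > 100000 nM, so no number is known for it. It sits at the limit of > 100000 nM in this assay, at which 1 of the 3 values shown sits, the weakest point among the three. The change from compound 3 to compound 4 `Cc1ccc(NC(=O)NC(=O)c2ccc(OCc3cccc(F)c3)cc2)cc1-c1nc2ccccc2[nH]1` is 3-fluorophenyl in place of 2,3-dichlorophenyl on a saturated chain carbon bound to an oxygen on an aromatic ring. Going by the values given here, two measured steps bear on this: an at least 4.8-fold higher number from compound 1 to compound 3 (0.68 log units; beyond the scatter) and an at least 39-fold higher number from compound 2 to compound 3 (1.59 log units; beyond the scatter), each moving toward a weaker inhibitor as chlorine entered, and compound 4 removes both chlorines. A large move toward a stronger inhibitor is therefore expected, an at least 10-fold lower number from compound 3 to compound 4 (1.00 log units; beyond the scatter). Compound 4 is estimated at 10000 nM, within a range from 2000 nM to 50000 nM.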

Compound 4, half-maximal inhibitory concentration: 44800 nM
Beside the measured number, compound 4's estimate is 4.5-fold (0.65 log units) below it; low and high end bracket the measured number.
By their numbers in this assay, from the lowest: compound 2; then compound 1; then compound 4. At a limit, above all of these: compound 3.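

Where the fluorine sits on this ring matters: 3-fluorophenyl in place of 2-fluorophenyl gives an 18-fold higher number from compound 2 to compound 4 (1.25 log units; beyond the scatter). Fluoro in place of chloro gives only a 2.2-fold higher number from compound 1 to compound 4 (0.33 log units; beyond the scatter), so compound 4 does not recover the strength of compound 2 simply by carrying fluorine. The step away from 2,3-dichlorophenyl, an at least 2.2-fold lower number from compound 3 to compound 4 (0.34 log units; beyond the scatter), gives only a bound, because one end of it is a limit: the limit of > 100000 nM in this assay, at which 1 of the 4 values shown sits.

Going by these compounds, whether a methoxy group or an amine on this ring would behave more like compound 2 or compound 4 stays open. On these data alone, the true number for compound 3 also stays open.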